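This account rests on a few compounds, and the source may have more. Where it says the series, first, only, none or still open, it means among the compounds named here.

Working notes on the series, read in a functional assay on the whole organism for inhibition, with Rattus norvegicus as the target; a lower number here means that less compound is needed, a higher number that more compound is needed for the effect. For the measured compounds named here, compound 3 `CCc1ccc(CC(C)(Oc2ccc(C(C)C)cc2)C(=O)O)cc1` stands at 0.1 mg/kg, the only true number so far. Compound 1 `CC(C)c1ccc(OC(C)(Cc2ccccc2)C(=O)O)cc1` gives > 10 mg/kg, which is a limit. Compound 2 `Cc1cccc(CC(C)(Oc2ccc(C(C)C)cc2)C(=O)O)c1` gives < 1 mg/kg, which is also a limit.

Methyl in place of hydrogen on an aromatic carbon gives an at least 10-fold lower number from compound 1 to compound 2 (1.00 log units; beyond the scatter). With ethyl instead, the result is an at least 100-fold lower number from compound 1 to compound 3 (2.00 log units; beyond the scatter). Both lie beyond the scatter, while the remaining comparison is a step that the limit leaves unreadable from compound 2 to compound 3.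

Compound 4 `CC(C)c1ccc(OC(C)(Cc2ccc(Cl)c(Cl)c2)C(=O)O)cc1` has 3,4-dichlorophenyl in place of 4-ethylphenyl on a saturated chain carbon, two bonds along the chain from a carbonyl carbon and an oxygen on an aromatic ring. Going by the values given here, no chlorine-bearing compound has been measured, so these steps carry over only loosely. Compound 4 keeps a substituted aromatic ring at this place, so most of the gain seen in an at least 100-fold lower number from compound 1 to compound 3 (2.00 log units; beyond the scatter) is expected to remain, with a small move toward a higher number. The estimated step is a 3.0-fold higher number from compound 3 to compound 4 (0.48 log units; beyond the scatter). For compound 4 the expected value is 0.3 mg/kg, with an estimated range of 0.05 mg/kg to 2 mg/kg.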

Compound 4, dose for half-maximal effect: 5 mg/kg
Compound 4: the middle estimate sits 17-fold (1.22 log units) below what was measured; the whole stated range lies below it.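

In this assay, a substituted aromatic ring at this saturated chain carbon does not by itself carry the gain, and the choice of substituents decides the outcome: 3,4-dichlorophenyl in place of 4-ethylphenyl gives a 50-fold higher number from compound 3 to compound 4 (1.70 log units; beyond the scatter). Set against the 3-methylphenyl ring, the same change gives an at least 5.0-fold higher number from compound 2 to compound 4 (0.69 log units; beyond the scatter), a step that can only be read as a floor: the limit of < 1 mg/kg in this assay, at which 1 of the 4 values shown sits. Set against the unsubstituted phenyl ring, the change gives an at least 2.0-fold lower number from compound 1 to compound 4 (0.30 log units; that floor lies within the scatter), so any real gain of 3,4-dichlorophenyl over phenyl remains unsettled: the limit of > 10 mg/kg in this assay, at which 1 of the 4 values shown sits.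

Going by these compounds, whether a 4-chlorophenyl ring at this place would stand closer to compound 3 or to compound 4 remains open. So does whether a 4-propylphenyl ring would hold the level of compound 3.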